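Moving the fluorine on the benzyl group of compound 3

The source may hold more compounds than are shown below. What is called first, only, known or untested is meant among the compounds shown, and "the series" means these compounds.

Values in an assay on lysate for inhibition of phosphatidylcholine:ceramide cholinephosphotransferase 2 (Homo sapiens), read by HPLC, with stated times of 30 min and 2 h (a higher number here means a weaker inhibitor, a lower number a stronger inhibitor), so far:
compound 1 `O=C(NCc1ccccc1)c1ccccc1OCc1ccccc1` gives 34200 nM
compound 2 `O=C(Nc1ccccn1)c1ccccc1OCc1ccccc1` gives 11700 nM
compound 3 `O=C(Nc1cccnc1)c1ccccc1OCc1ccccc1F` gives 3500 nM

Compound 3 has the lowest number of the three; compound 2 is nearest and compound 1 furthest, both beyond the scatter. Compound 4 `O=C(Nc1cccnc1)c1ccccc1OCc1cccc(F)c1` keeps the core of compound 3 and differs only by 3-fluorophenyl in place of 2-fluorophenyl on a saturated chain carbon bound to an oxygen on an aromatic ring. Among the compounds with values here, the one measured step, a 2.9-fold lower number from compound 1 to compound 2 (0.47 log units; beyond the scatter), concerns the amide nitrogen, not the benzyl ether, so it offers no guide here; no measured pair moves the fluorine around the ring. Compound 4 is therefore expected near compound 3, with no change at the digits printed from compound 3 to compound 4 (within the scatter), no step beyond the scatter. Estimate for compound 4 in this assay: 3500 nM, range 1500 nM to 8000 nM.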

Compound 4, half-maximal inhibitory concentration: 1600 nM
Compound 4: middle estimate off by 2.2-fold (0.34 log units), on the high side; the range from low to high includes it.
By their numbers in this assay, from the lowest: compound 4; then compound 3; then compound 2; then compound 1.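

Within the data shown here, this is the first step measured at the benzyl ether rather than the amide nitrogen: in this assay, 3-fluorophenyl in place of 2-fluorophenyl on a saturated chain carbon bound to an oxygen on an aromatic ring gives a 2.2-fold lower number from compound 3 to compound 4 (0.34 log units; beyond the scatter) with no change in atom count. The number is therefore sensitive to where the fluorine sits, not only to which atoms are present. No evidence on the origin of this step is available. Still open, from the compounds shown here alone, is how 4-fluorophenyl would compare at this place, and whether plain phenyl, or an amine or a carboxylic acid on that ring, would fit the same trend.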